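The compounds below may be only part of what the source reports. "The series", "measured", "known", "first", "only" and "open" are said of these compounds alone.

Compound 1 `CC(=O)Nc1ccc2oc(-c3ccccc3F)cc(=O)c2c1`: > 125000 nM (a limit of the assay)
Compound 2 `COc1cccc(-c2oc3ccc(NC(C)=O)cc3c(=O)c2O)c1`: 50000 nM

Among the measured compounds shown here, only two compounds have been tested so far, both in an ADME assay on THP-1 cells (Homo sapiens) for cytotoxicity, read by flow cytometry and propidium iodide staining, with a stated time of 72 h; on this read-out lower numbers stand for stronger inhibition and higher numbers for weaker inhibition. For the measured compounds named here, compound 2 gives 50000 nM, the only true number available. Compound 1 gives > 125000 nM, which is a limit of the assay and not a number.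

The next compound to be tested is compound 3 `CC(=O)Nc1ccc2oc(-c3ccccc3F)c(O)c(=O)c2c1`. It has 2-fluorophenyl in place of 3-methoxyphenyl on an aromatic carbon, next to the ring oxygen and ortho to a hydroxy group: 2-fluorophenyl in place of 3-methoxyphenyl on an aromatic carbon. The rest of compound 2 stays the same.

Going by the values given here, the two tested compounds do not differ in just one place, so the data offer no measured step to serve as a guide. With compound 2 at 50000 nM as the only numerical anchor, this swap is expected to cause no change beyond the usual scatter in this assay. The estimated change is a 1.2-fold higher number from compound 2 to compound 3 (0.08 log units; within the scatter). For compound 3 the estimated value is 60000 nM, with an expected range of 25000 nM to 125000 nM.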

Compound 3, half-maximal inhibitory concentration: 47000 nM
The estimate for compound 3 lay 1.3-fold (0.11 log units) above the measured number; the range from low to high includes it.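

In this assay, the swap of 3-methoxyphenyl for 2-fluorophenyl, on an aromatic carbon next to the ring oxygen and ortho to a hydroxy group, gives a 1.1-fold lower number from compound 2 to compound 3 (0.03 log units; within the scatter), so with the hydroxy group in place these two aromatic groups cannot be told apart at this position. Among the compounds shown here, the other change, hydroxy in place of hydrogen on an aromatic carbon with 2-fluorophenyl kept, gives an at least 2.6-fold lower number from compound 1 to compound 3 (0.42 log units; beyond the scatter), which is the first single change seen here to move the number beyond the scatter. Compound 1 stands at a limit of the assay and not at a true number, so the full size of this step stays unknown: the limit of > 125000 nM in this assay, at which 1 of the 3 values shown sits.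

The compounds shown leave open whether the hydroxy group gives a similar step when 3-methoxyphenyl is the neighbouring aromatic group, since that step is seen only with 2-fluorophenyl. They also leave open how the number would respond if an amine or a carboxylic acid stood in the place of the hydroxy group.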